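Acetylation of the aromatic amine on two related cores

This account rests on a few compounds, and the source may have more. Where it says the series, first, only, none or still open, it means among the compounds named here.

Measured compounds:
compound 1, `Nc1cc(OCc2ccccc2)nc(SCc2ccccc2)n1`: 53700 nM
compound 2, `CC(=O)Nc1cc(OCc2ccccc2)nc(SCc2ccccc2)n1`: 40000 nM
compound 3, `Nc1cc(=O)n(Cc2ccccc2)c(SCc2ccccc2)n1`: 84900 nM

All three were tested in a functional assay on LoVo cells (Homo sapiens) for antiproliferative activity, read by MTT assay, with a stated time of 72 h; a lower number here means a stronger inhibitor of growth, a higher number a weaker inhibitor of growth. Compound 1 gives 53700 nM and its acetylated counterpart, compound 2, gives 40000 nM. The change between them is acetyl in place of hydrogen on a nitrogen on an aromatic ring, and the step it made is a 1.3-fold lower number from compound 1 to compound 2 (0.13 log units; within the scatter), so the two numbers cannot be told apart. Compound 3 gives 84900 nM in this assay ; its core has the same atoms as that of compound 1 joined differently, and the difference between the two cores is not broken down here. Compound 3 and compound 1 lie within the scatter of each other, while compound 2 stands beyond the scatter from compound 3.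

Compound 4, `CC(=O)Nc1cc(=O)n(Cc2ccccc2)c(SCc2ccccc2)n1`, has not been measured. It differs from compound 3 by acetyl in place of hydrogen on a nitrogen on an aromatic ring, the same change as from compound 1 to compound 2, at a place described in the same words. For the measured compounds named here, the only guide is the step from compound 1 to compound 2, which was within the scatter. Compound 4 is therefore expected to sit close to compound 3, with an estimated step of a 1.3-fold lower number from compound 3 to compound 4 (0.12 log units; within the scatter) in this assay , because the earlier step was a 1.3-fold lower number from compound 1 to compound 2 (0.13 log units; within the scatter). The estimate for compound 4 is 65000 nM in this assay , with a range from 30000 nM to 150000 nM.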

Compound 4, concentration for 50% growth inhibition: 56300 nM
Estimate against measurement, compound 4: 1.2-fold (0.06 log units) above, within the range that was stated.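

In this assay the swap of acetyl for hydrogen on the nitrogen gives a 1.5-fold lower number from compound 3 to compound 4 (0.18 log units; within the scatter) and so leaves the two numbers on this core indistinguishable, as on the core of compound 1. Set side by side, the two steps agree, and the change carries over from one core to the other without a detectable difference in size: the same change on two cores in this assay, a 1.3-fold lower number (0.13 log units; within the scatter) from compound 1 to compound 2 and a 1.5-fold lower number (0.18 log units; within the scatter) from compound 3 to compound 4, 1.1-fold (0.05 log units) apart, within the scatter of two such steps. This agreement is only between two steps that each lie within the scatter, so it shows that amino to acetamido makes no clear difference on either core, not that acetylation lowers the number, and it does not show that a larger step would carry over in the same way, nor does a pair of cores establish a rule for the wider series.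

The compounds shown leave open whether another group on that nitrogen, such as a longer acyl chain like butanoyl or a methanesulfonyl group, would move the number beyond the scatter on either core. Also open, going by these compounds, is whether a change elsewhere in the molecule, such as a carboxylic acid or an amine on either benzyl group, would alter the number or change how the acetyl step reads.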